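From Methoxy to Chloro at the Assay Limit

This account rests on a few compounds, and the source may have more. Where it says the series, first, only, none or still open, it means among the compounds named here.

In a functional assay on HepG2 cells (Homo sapiens) for antiproliferative activity, read by MTT assay, with a stated time of 72 h (a lower number here means a stronger inhibitor, a higher number a weaker inhibitor), compound 3 (`COc1ccc(N2C(=O)COc3ccc(-c4cnc5ccccc5c4)cc32)cc1`) gives > 40000 nM, which is a limit and not a number. Compound 1 (`COc1ccc(N2C(=O)COc3ccc(-c4cnc(Cl)c(NS(=O)(=O)c5ccc(F)cc5)c4)cc32)cc1`) gives > 40000 nM, also a limit. Compound 2 (`O=C1COc2ccc(-c3cnc4ccccc4c3)cc2N1C1CCCCC1`) gives > 40000 nM, again a limit. Compound 3 therefore stands with the other two at the limit of > 40000 nM in this assay, at which 3 of the 3 values shown sit.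

Compound 4 (`O=C1COc2ccc(-c3cnc4ccccc4c3)cc2N1c1ccc(Cl)cc1`) carries chloro in place of methoxy on an aromatic carbon, para to a large group (chloro in place of methoxy on an aromatic carbon). Within the data shown here, the only measured step that bears on this is a step that the two limits leave unreadable from compound 2 to compound 3. It offers no size to carry over, so no step beyond the scatter is expected in this assay. The expected step is a number no higher from compound 3 to compound 4 (the limit leaves the size open). Compound 4 is estimated at 40000 nM, with an expected range from 15000 nM to 80000 nM.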

Compound 4, half-maximal inhibitory concentration: 32700 nM
Estimate against measurement, compound 4: 1.2-fold (0.09 log units) above; measured number inside the range.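

At this position, chloro in place of methoxy yields the only number among the compounds shown, yet in this assay the change amounts to an at least 1.2-fold lower number from compound 3 to compound 4 (0.08 log units; that floor lies within the scatter). Against the cyclohexyl group, 4-chlorophenyl gives an at least 1.2-fold lower number from compound 2 to compound 4 (0.08 log units; that floor lies within the scatter). The other values are limits and not numbers: the limit of > 40000 nM in this assay, at which 3 of the 4 values shown sit.

On these data alone, the true size of both steps stays open, and neither can be said to go beyond the scatter. Also open, as far as these compounds go, is whether an amine or a carboxylic acid in place of chloro would give a clearly lower number than compound 4.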